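A few compounds are considered here, and "the series" means these few. Any claim that something is new, unique, unknown or untested is made for them only; others in the source may bear on it.

Values in a functional assay on HepG2 cells (Homo sapiens) for inhibition, read by fluorescence and resazurin assay, with a stated time of 72 h; a lower number here means a stronger inhibitor, a higher number a weaker inhibitor:
- compound 1 `O=C(Nc1ccccc1)Nc1cccc(Nc2nccc(Nc3ccc4cn[nH]c4c3)n2)c1` gives 8200 nM
- compound 2 `O=C(Nc1ccccc1)Nc1cccc(Nc2ncc(Cl)c(Nc3ccc4cn[nH]c4c3)n2)c1` gives 3500 nM
- compound 3 `O=C(Nc1ccccc1)Nc1cccc(Nc2nccc(Nc3ccc4[nH]ncc4c3)n2)c1` gives 8100 nM

Compound 3 stands level with compound 1, as a 1.0-fold lower number from compound 1 to compound 3 (0.01 log units; within the scatter) shows, and compound 2 has the lowest number of the three. The next compound, compound 4 `O=C(Nc1ccccc1)Nc1cccc(Nc2nccc(Nc3ccc4cc[nH]c4c3)n2)c1`, differs from compound 3 as follows: 1H-indol-6-yl in place of 1H-indazol-5-yl on a nitrogen on an aromatic ring. In short, 1H-indol-6-yl stands in place of 1H-indazol-5-yl on a nitrogen on an aromatic ring.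

The closest evidence is a 1.0-fold lower number from compound 1 to compound 3 (0.01 log units; within the scatter), where 1H-indazol-5-yl replaced 1H-indazol-6-yl at that same place. The other measured change, a 2.3-fold lower number from compound 1 to compound 2 (0.37 log units; beyond the scatter), is chloro in place of hydrogen on an aromatic carbon, which compound 4 does not carry. Among the compounds with values here, no measured step exchanges an indazolyl for an indolyl group, so the expectation is uncertain. In this assay, no change beyond the scatter is expected, and the estimated step is a 1.2-fold lower number from compound 3 to compound 4 (0.06 log units; within the scatter). The estimate for compound 4 is 7000 nM, with an expected range of 3000 nM to 16000 nM.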

Compound 4, half-maximal inhibitory concentration: 3200 nM
For compound 4 the middle estimate is 2.2-fold (0.34 log units) above the measured one; measured number inside the range.
By their numbers in this assay, from the lowest: compounds 4 and 2 (each within the scatter of the next); then compounds 3 and 1 (each within the scatter of the next).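

At this place, on a nitrogen on an aromatic ring, the choice of group does register in this assay: 1H-indol-6-yl gives a 2.5-fold lower number from compound 3 to compound 4 (0.40 log units; beyond the scatter) and a 2.6-fold lower number from compound 1 to compound 4 (0.41 log units; beyond the scatter), both modest but beyond the scatter. Within the data shown here, the earlier exchange of 1H-indazol-6-yl for 1H-indazol-5-yl stayed within the scatter, so this is the first change at this place to move the number, and the entering group has 1 hetero atom in its five-membered ring where the indazolyl groups have 2. Nothing available explains why the number falls with this change.

Going by these compounds, how 1H-indol-5-yl or a plain phenyl group would behave at this place remains open. So does whether the chloro of compound 2 would add to the step seen with compound 4.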